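The compounds below may be only part of what the source reports. "The series", "measured", "known", "first", "only" and "open" are said of these compounds alone.

For the measured compounds named here, compound 1 `CC(Oc1ccccc1S(C)(=O)=O)C1=NCCN1` gives 0.6 in an assay on CHO cells with Alpha-2C adrenergic receptor (Homo sapiens) as the target (a lower number here means a smaller maximal response, a higher number a larger maximal response), and compound 2 `C=COc1ccccc1OC(C)C1=NCCN1` gives 0.48, the lowest of the two numbers measured so far. Going by the values given here, the single measured step, a number 0.12 lower from compound 1 to compound 2 (beyond the scatter), shows that exchanging the group on this aromatic carbon shifts intrinsic activity modestly. Compound 3 `CC(Oc1ccccc1C=O)C1=NCCN1` differs from compound 2 as follows: formyl in place of vinyloxy on an aromatic carbon. The earlier step bears on this only in showing that the group on that carbon matters. A modest rise back toward compound 1 is expected, a number 0.070 higher from compound 2 to compound 3 (within the scatter) in this assay. Compound 3 is accordingly estimated at 0.55, within 0.4 to 0.7.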

Compound 3, intrinsic activity: the largest response reached, as a fraction of the reference agonist's: 0.6
Beside the measured number, compound 3's estimate is 0.050 below it; the range from low to high includes it.
By their numbers in this assay, from the lowest: compound 2; then compounds 1 and 3 (each within the scatter of the next).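

In this assay, formyl in place of vinyloxy on this aromatic carbon gives a number 0.12 higher from compound 2 to compound 3 (beyond the scatter), while formyl in place of methylsulfonyl gives no change at the digits printed from compound 1 to compound 3 (within the scatter). Formyl and methylsulfonyl therefore read alike at this position, and of the three groups only vinyloxy stands apart. No evidence on the properties of these groups accompanies this result.

For the compounds shown here, with vinyloxy in compound 2 as the only group that separates, no trend across groups can be stated. On these data alone, how an amine, a carboxylic acid or a longer chain on this carbon would read remains open.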